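The source may report more compounds than this note shows. Statements on the series, on what has been measured and on what is new or still open speak of the compounds shown alone.

Two compounds share one core and differ only in the group attached to a triple-bonded carbon. Compound 1 `Cc1ccc(C#Cc2cn(C/C=C\CN3C(=O)c4ccccc4C3=O)c(=O)[nH]c2=O)cc1` carries 4-methylphenyl there; in a functional assay on SW-620 cells (Homo sapiens) for antiproliferative activity, read by MTT assay, with a stated time of 3 days (a lower number here means a stronger inhibitor, a higher number a weaker inhibitor), compound 1 gives > 100000 nM, which is a limit of the assay and not a number. Within the data shown here, compound 2 `CCCCCCCCC#Cc1cn(C/C=C\CN2C(=O)c3ccccc3C2=O)c(=O)[nH]c1=O` carries octyl in that place; in this assay compound 2 gives 67000 nM, the only number measured so far. The measured step is an at least 1.4-fold lower number from compound 1 to compound 2 (0.17 log units; that floor lies within the scatter), and its floor lies within the scatter, so it shows at most a small gain.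

Compound 3 `O=C1c2ccccc2C(=O)N1C/C=C\Cn1cc(C#Cc2ccc(Br)cc2)c(=O)[nH]c1=O` has not been measured. Its difference from compound 2 is 4-bromophenyl in place of octyl on a triple-bonded carbon. Among the measured compounds shown here, this runs opposite to the one measured step, since an aromatic ring returns where a chain stood. Because the step of an at least 1.4-fold lower number from compound 1 to compound 2 (0.17 log units; that floor lies within the scatter) ran from a limit to a weak number, the return to an aromatic ring is expected to push the number back up, quite possibly to the limit again. Compound 3 is therefore expected to give about 100000 nM in this assay, within a range from 40000 nM to 250000 nM. The step this estimate implies, a 1.5-fold higher number from compound 2 to compound 3 (0.17 log units; within the scatter), is an expectation only.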

Compound 3, half-maximal inhibitory concentration: > 100000 nM
Compound 3: only a limit was reported; the forecaster's own chance of this, stated with the estimate: 55%; the middle value lies on the limit itself.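

Compound 3 puts a second aromatic group on the triple-bonded carbon, 4-bromophenyl where compound 1 has 4-methylphenyl, so the octyl chain of compound 2 is now set against two aromatic groups rather than one. The new step, an at least 1.4-fold higher number from compound 2 to compound 3 (0.17 log units; that floor lies within the scatter), still does not establish a real difference between the chain and the ring, even though it mirrors the earlier step in the opposite direction. Bromo in place of methyl cannot be judged, since the step between the two aromatic compounds cannot be read, and what they share is a limit of the assay and not a number: the limit of > 100000 nM in this assay, at which 2 of the 3 values shown sit.

Open, from the compounds shown here alone, is whether any group on this triple-bonded carbon gives a clearly lower number in this assay, given that compound 2 reads only 67000 nM. A longer chain than octyl, a shorter one such as butyl, a chain ending in an amine or a carboxylic acid, or a phenyl ring carrying a hydroxyl group could each be compared directly with compound 2 or compound 3.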